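A few compounds are considered here, and "the series" means these few. Any claim that something is new, unique, unknown or untested is made for them only; others in the source may bear on it.

Measured compounds in an ADME assay on cells (Homo sapiens) for cytotoxicity, read by polymerase chain reaction, with a stated time of 3 days; on this read-out lower numbers stand for higher toxicity in this test and higher numbers for lower toxicity in this test:
- compound 1 `CN(C)c1ccc2nc(-c3c(Cl)nc(N)nc3N[C@@H]3C[C@H](CO)[C@@H](O)[C@H]3O)sc2c1`, compound 1 gives > 25000 nM
- compound 2 `CN(C)c1ccc2sc(-c3c(Cl)nc(N)nc3N[C@@H]3C[C@H](CO)[C@@H](O)[C@H]3O)nc2c1`, compound 2 gives 25000 nM
- compound 3 `Cc1nc(NC(C)C)nc(N[C@@H]2C[C@H](CO)[C@@H](O)[C@H]2O)c1-c1nc2ccccc2s1`, compound 3 gives 13000 nM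

The value for compound 1 is a limit of the measurement, not a number, as noted in the limit of > 25000 nM in this assay, at which 1 of the 3 values shown sits. Of the two numbers, compound 3 and compound 2 sit within the usual scatter of each other, so neither can be called the more or less toxic of the two. No step between compounds differing in one place is shown, so there is no measured pattern to lean on.

Compound 4 `Cc1nc(NCc2nccs2)nc(N[C@@H]2C[C@H](CO)[C@@H](O)[C@H]2O)c1-c1nc2ccccc2s1` differs from compound 3 in one place: (1,3-thiazol-2-yl)methyl in place of isopropyl on a nitrogen on an aromatic ring. The account expects this exchange to leave the read-out in this assay essentially where compound 3 sits, with any shift no larger than the scatter, and the expected step is a 1.2-fold higher number from compound 3 to compound 4 (0.06 log units; within the scatter). Compound 4 is therefore estimated at 15000 nM, within a range from 5000 nM to 40000 nM.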

Compound 4, half-maximal cytotoxic concentration: 23000 nM
Estimate against measurement, compound 4: 1.5-fold (0.19 log units) below; the measured number falls inside the stated range.
By their numbers in this assay, from the lowest: compounds 3, 4 and 2 (each within the scatter of the next).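

At the nitrogen on the aromatic ring, (1,3-thiazol-2-yl)methyl replaces isopropyl, bringing in a five-membered aromatic ring, and this assay records a 1.8-fold higher number from compound 3 to compound 4 (0.25 log units; within the scatter). For the compounds shown here, this is the first comparison that differs in one place, and it shows that this position can carry a group with a ring and more heavy atoms without a change beyond the scatter. Compound 1 carries a limit and not a number, so the read-out has an upper end: the limit of > 25000 nM in this assay, at which 1 of the 4 values shown sits.

One exchange gives no rule for this position, and it cannot say whether the read-out would hold with a carboxylic acid or a longer chain on this nitrogen. It also leaves open whether the same exchange would behave alike on the core of compound 1 or compound 2.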